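The compounds below may be only part of what the source reports. "The series", "measured", "known", "first", "only" and "open" are said of these compounds alone.

Of the compounds shown here, two of the shared core have been measured in a functional assay on HL-60 cells (Homo sapiens) for antiproliferative activity, read by MTT assay, with a stated time of 24 h; on this read-out lower numbers stand for stronger inhibition and higher numbers for weaker inhibition. Compound 1 `CNC(=O)c1ccccc1Oc1nc(Nc2ccc(C(F)(F)F)cc2)ncc1Br` returns only a limit of the assay, > 50000 nM, and no number. Going by the values given here, compound 2 `CNC(=O)c1ccccc1Oc1nc(Nc2ccc(C)cc2C)ncc1Br` gives 32300 nM in this assay, which is the only number on the series so far. The remaining value, that of compound 1, is a limit (the limit of > 50000 nM in this assay, at which 1 of the 2 values shown sits). Compound 3 `CNC(=O)c1ccccc1Oc1nc(Nc2cccc(C(C)C)c2)ncc1Br` is not yet measured. It differs from compound 2 by 3-isopropylphenyl in place of 2,4-dimethylphenyl on a nitrogen on an aromatic ring; the rest of the core is unchanged. Among the compounds with values here, no step between measured compounds exists to set a scale for a change of this kind. Compound 2 stands at 32300 nM, and no shown step points elsewhere. The expected step is a 1.0-fold higher number from compound 2 to compound 3 (0.01 log units; within the scatter), which is not beyond the usual scatter. For compound 3 the estimate in this assay is 33000 nM, with a range from 12000 nM to 90000 nM, and a real chance that only a limit is returned.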

Compound 3, half-maximal inhibitory concentration: 17500 nM
Compound 3: middle estimate off by 1.9-fold (0.28 log units), on the high side, and the stated range covers the measured number.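

In this assay, going by these compounds alone, the exchange of 2,4-dimethylphenyl for 3-isopropylphenyl on a nitrogen on an aromatic ring gives the series its first readable step, a 1.8-fold lower number from compound 2 to compound 3 (0.27 log units; within the scatter), and so a first scale for a change at this place. Both groups are six-membered aromatic rings of carbon only, with no hydrogen-bond donors or acceptors and no net charge, and this one exchange between them stays within the scatter. Within the data shown here, compound 1 remains a limit of the assay and yields no step: the limit of > 50000 nM in this assay, at which 1 of the 3 values shown sits.

From the compounds shown here alone, whether an amine or a carboxylic acid on the aromatic ring at this place would carry the read-out beyond the scatter stays open. Also open, going by these compounds, is how far this single step speaks for other changes on the shared core.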